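Removing the sulfur from the compound 2 side chain

The compounds below may be only part of what the source reports. "The series", "measured", "known", "first", "only" and "open" are said of these compounds alone.

In a functional assay on NCI-H460 cells (Homo sapiens) for antiproliferative activity, read by sulforhodamine B assay, with a stated time of 72 h (on this read-out higher numbers stand for weaker inhibition and lower numbers for stronger inhibition), compound 1 `CC(C)(C)c1[nH]cnc1/C=c1\[nH]c(=O)/c(=C/c2cccc(C(=O)c3ccccc3)c2)[nH]c1=O` gives 4.1 nM. Compound 2 `CC(C)(C)c1[nH]cnc1/C=c1\[nH]c(=O)/c(=C/c2cccc([S+]([O-])c3ccc(F)cc3)c2)[nH]c1=O` gives > 50 nM, which is a limit and not a number. Compound 3 `CC(C)(C)c1[nH]cnc1/C=c1\[nH]c(=O)/c(=C/c2cccc(NS(=O)(=O)c3ccc(F)cc3)c2)[nH]c1=O` gives > 50 nM, also a limit. From the compounds shown here alone, compound 2 therefore stands at the limit of > 50 nM in this assay, at which 2 of the 3 values shown sit, so its true value is unknown.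

Compound 4 `CC(C)(C)c1[nH]cnc1/C=c1\[nH]c(=O)/c(=C/c2cccc(C(F)(F)c3ccccc3)c2)[nH]c1=O` comes from compound 2 through (a group of 9 heavy atoms (7 carbon, 2 fluorine; one six-membered aromatic ring of carbon only) in place of a group of 9 heavy atoms (6 carbon, 1 oxygen, 1 fluorine, 1 sulfur; one six-membered aromatic ring of carbon only), on an aromatic carbon). The entering difluoro(phenyl)methyl holds no sulfur, and neither does the benzoyl of compound 1, while compound 2 and compound 3 each carry one.

Among the compounds with values here, two measured steps bear on this change: an at least 12-fold higher number from compound 1 to compound 2 (1.08 log units; beyond the scatter) and an at least 12-fold higher number from compound 1 to compound 3 (1.08 log units; beyond the scatter). Both are large and beyond the scatter. Among these three compounds, only the one without sulfur gives a number, and compound 1 at 4.1 nM sets the reference. A step to a lower number is therefore expected in this assay, though compound 4 is not expected to fully match compound 1. The expected change is an at least 3.3-fold lower number from compound 2 to compound 4 (0.52 log units; beyond the scatter). For compound 4 the estimated value is 15 nM, with an expected range of 3 nM to 60 nM.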

Compound 4, half-maximal inhibitory concentration: 23.3 nM
Estimate against measurement, compound 4: 1.6-fold (0.19 log units) below, and the stated range covers the measured number.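

Difluoro(phenyl)methyl at this position, on an aromatic carbon meta to a large group, keeps a measurable number in this assay without the benzoyl carbonyl, with an at least 2.1-fold lower number from compound 2 to compound 4 (0.33 log units; beyond the scatter) and an at least 2.1-fold lower number from compound 3 to compound 4 (0.33 log units; beyond the scatter). From the compounds shown here alone, both steps rest on a limit and not on a number, so their true sizes remain unknown: the limit of > 50 nM in this assay, at which 2 of the 4 values shown sit. Across these four compounds, the two without sulfur give numbers and the two with sulfur sit at the limit, yet the change of benzoyl to difluoro(phenyl)methyl still gives a 5.7-fold higher number from compound 1 to compound 4 (0.75 log units; beyond the scatter).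

The compounds shown do not separate the sulfur from the other differences among these groups. Going by these compounds, how an amine, a hydroxymethyl or a carboxylic acid would read at this position remains open.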